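The source may hold more compounds than are shown below. What is called first, only, known or untested is meant among the compounds shown, and "the series" means these compounds.

Of the compounds shown here, three built on one shared core have been measured in a functional assay on Shh Light II cells (Mus musculus) for inhibition, read by a luciferase reporter; on this read-out lower numbers stand for stronger inhibition and higher numbers for weaker inhibition. Compound 1 `O=C(CC1CCCCCC1)N1CCC(c2nc(-c3ccc4ccccc4n3)no2)CC1` gives 840 nM in this assay, the highest of the three numbers. Compound 2 `N#Cc1ccccc1NC(=O)N1CCC(c2nc(-c3ccc4ccccc4n3)no2)CC1` gives 190 nM, and compound 3 `CC(=O)N1CCC(NC(=O)N2CCC(c3nc(-c4ccc5ccccc5n4)no3)CC2)CC1` gives 500 nM. The step of a 4.4-fold lower number from compound 1 to compound 2 (0.65 log units; beyond the scatter) lies beyond the scatter, whereas the step of a 1.7-fold lower number from compound 1 to compound 3 (0.23 log units; within the scatter) does not; between the two ureas themselves, the step of a 2.6-fold higher number from compound 2 to compound 3 (0.42 log units; beyond the scatter) is modest. Compound 4 `O=C(Nc1ncccc1Cl)N1CCC(c2nc(-c3ccc4ccccc4n3)no2)CC1` has not yet been measured. It differs from compound 1 in a single place: (3-chloropyridin-2-yl)amino in place of cycloheptylmethyl on a carbonyl carbon. As in compound 2, an aromatic amino group now sits on the carbonyl carbon, so the change from compound 1 to compound 2 bears most directly on it, while the change from compound 1 to compound 3, with its (1-acetylpiperidin-4-yl)amino group, stayed within the scatter. Compound 4 is therefore expected to show the step of a 3.4-fold lower number from compound 1 to compound 4 (0.53 log units; beyond the scatter), a decrease of comparable size to what was seen because of a 4.4-fold lower number from compound 1 to compound 2 (0.65 log units; beyond the scatter). Compound 4 is thus estimated to give about 250 nM in this assay, within a range from 100 nM to 600 nM.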

Compound 4, half-maximal inhibitory concentration: 2800 nM
Beside the measured number, compound 4's estimate is 11-fold (1.05 log units) below it; measured number above the stated range.
By their numbers in this assay, from the lowest: compound 2; then compounds 3 and 1 (each within the scatter of the next); then compound 4.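

In this assay, an aromatic amino group on the carbonyl carbon does not by itself bring a lower number: the step of a 15-fold higher number from compound 2 to compound 4 (1.17 log units; beyond the scatter), with 3-chloropyridin-2-yl in place of 2-cyanophenyl on the amide-type nitrogen, is the largest seen here, so this position separates these two aromatic groups sharply. Replacing cycloheptylmethyl at this place can also raise the number, as the step of a 3.3-fold higher number from compound 1 to compound 4 (0.52 log units; beyond the scatter) shows, and the step of a 5.6-fold higher number from compound 3 to compound 4 (0.75 log units; beyond the scatter) places this aromatic group behind the non-aromatic 1-acetylpiperidin-4-yl group, the reverse of the order of compound 2 and compound 3. Nothing given here accounts for the gap between the two aromatic groups.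

On these data alone, it remains open whether the higher number goes with the ring nitrogen or with the chlorine of the 3-chloropyridin-2-yl group, which a plain phenyl or a 2-chlorophenyl group on the amide-type nitrogen could help to settle. As far as these compounds go, how a methoxy group in place of the chlorine would read also remains open.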